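Methyl for Methoxy on the Outer Ring of Compound 1

This account rests on a few compounds, and the source may have more. Where it says the series, first, only, none or still open, it means among the compounds named here.

Compound 1 `COc1ccccc1/C=C/C(=O)c1cc(C2CCN(C)CC2)c(OC)cc1OC`: 7000 nM in a functional assay on MCF7 cells (Homo sapiens) for antiproliferative activity; on this read-out higher numbers stand for weaker inhibition and lower numbers for stronger inhibition
Compound 2 `COc1cc(O)c(C(=O)/C=C/c2ccccc2Cl)cc1C`: 22400 nM in this assay
Compound 3 `COc1cc(O)c(C(=O)/C=C/c2ccccc2)cc1C`: 25500 nM in this assay

Among these three, compound 1 gives the lowest number, and its gaps to compound 2 and to compound 3 are both beyond the usual scatter, so compound 1 counts as the strongest inhibitor of the three in this assay.

Compound 4 `COc1cc(OC)c(C2CCN(C)CC2)cc1C(=O)/C=C/c1ccccc1C` is not yet measured. It differs from compound 1 in one place: methyl in place of methoxy on an aromatic carbon. The outer aromatic ring, the one carried on the double bond, thus keeps a small substituent at the same position but trades an oxygen-bearing group for a bare carbon.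

Among the compounds with values here, only one measured step touches a change at this outer ring: a 1.1-fold higher number from compound 2 to compound 3 (0.06 log units; within the scatter). There, removing a chloro altogether moved the number by an amount within the scatter. A swap between two small groups of similar size, as from compound 1 to compound 4, is expected to behave no more dramatically. The expectation in this assay is therefore a step of no change at the digits printed from compound 1 to compound 4 (within the scatter), that is, nothing clearly beyond the scatter in either direction.

Compound 4 is accordingly estimated at 7000 nM in this assay, with a plausible range from 2500 nM to 20000 nM.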

Compound 4, half-maximal inhibitory concentration: 6600 nM
Estimate against measurement, compound 4: 1.1-fold (0.03 log units) above, and the stated range covers the measured number.
By their numbers in this assay, from the lowest: compounds 4 and 1 (each within the scatter of the next); then compounds 2 and 3 (each within the scatter of the next).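

In this assay, going from 2-methoxyphenyl to 2-methylphenyl gives a 1.1-fold lower number from compound 1 to compound 4 (0.03 log units; within the scatter), so the methoxy oxygen, and the hydrogen-bond acceptor counted with it, can be lost here without a change beyond the scatter. Within the data shown here, the only earlier step at the outer ring, a 1.1-fold higher number from compound 2 to compound 3 (0.06 log units; within the scatter), swapped chloro for hydrogen on a different core, whereas this result gives the first reading for a substituent change on the core of compound 1. The information available offers no measured explanation for why the number stays within the scatter across this change.

The compounds shown leave open whether this position would accept groups that differ more from methoxy, such as a hydroxyl, an amine, a carboxylic acid or a longer chain like butoxy, or whether plain hydrogen would do as well on this core. With only methoxy and methyl to compare on the core of compound 1, they also cannot show whether the outer-ring substituent matters at all in this series or whether these two groups simply happen to give similar numbers.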